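The compounds below may be only part of what the source reports. "The series", "measured", "known", "first", "only" and "open" are said of these compounds alone.

Measured compounds:
Compound 1, `N#Cc1cccc(N/C(=N\O)c2nonc2SCCNC(=O)CS(N)(=O)=O)c1`: in an ADME assay on microsomes from liver (Homo sapiens) for metabolic stability (a lower number here means that the compound disappears faster, a higher number that the compound lasts longer), compound 1 gives > 3 h, which is a limit of the assay rather than a number.
Compound 2, `N#Cc1cc(N/C(=N\O)c2nonc2SCCNC(=O)CS(N)(=O)=O)ccc1F`: in this assay compound 2 gives > 3 h, again a limit of the assay rather than a number.

Compound 2 thus stands at the upper edge of what this assay can report, and compound 1 stands in the same place, since (the limit of > 3 h in this assay, at which 2 of the 2 values shown sit). Going by the values given here, the one measured step, a step that the two limits leave unreadable from compound 1 to compound 2, therefore has no readable size. Compound 3, `NS(=O)(=O)CC(=O)NCCSc1nonc1/C(=N/O)Nc1ccc(F)c(Br)c1`, differs from compound 2 in one place: bromo in place of cyano on an aromatic carbon. Among the compounds with values here, no measured step involves a change of this kind, and the only step available carries no size, so the data give no direction for this assay here. Compound 3 is expected to stand at much the same place as the measured pair, with an estimate of 3 h, ranging from 1.5 h to 6 h. That amounts to an expected step of a number no higher from compound 2 to compound 3 (the limit leaves the size open), most likely again reported only as a limit.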

Compound 3, half-life: 2.37 h
The estimate for compound 3 lay 1.3-fold (0.10 log units) above the measured number, and the stated range covers the measured number.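

Going by these compounds alone, at this position on the ring, on a carbon ortho to a fluoro group, bromo in place of cyano gives the first number that is not a limit of the assay: in this assay compound 3 gives 2.37 h. The change reads as an at least 1.2-fold lower number from compound 2 to compound 3 (0.10 log units; that floor lies within the scatter), and the wider change from 3-cyanophenyl to 3-bromo-4-fluorophenyl reads as an at least 1.2-fold lower number from compound 1 to compound 3 (0.10 log units; that floor lies within the scatter). These are floors and not sizes, so the data do not establish a real difference from the other two compounds, whose values remain limits: the limit of > 3 h in this assay, at which 2 of the 3 values shown sit.

Going by these compounds, how far a chloro, methoxy or amino group at this position would move the number in this assay remains open. So does whether the bromo compound would read the same without its fluoro group.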